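Nitro in place of amino: compound 3 to compound 4

The compounds below may be only part of what the source reports. "The series", "measured", "known", "first", "only" and "open" are said of these compounds alone.

Values in an ADME assay on cells (Hepatocyte, Homo sapiens) for metabolic stability, with a stated time of 30 min (a higher number here means that more of the compound is left, a lower number that less of the compound is left), so far:
- compound 1 `O=C(OC1CCC(CN2CCN(c3cc(=O)c4cc(C(F)(F)F)cc([N+](=O)[O-])c4s3)CC2)CC1)c1ccccc1` gives 56.4%
- compound 2 `O=C(OC1CCC(CN2CCN(c3cc(=O)c4cc(C(F)(F)F)cc([N+](=O)[O-])c4s3)CC2)CC1)c1ccco1` gives 1%
- compound 3 `Nc1cc(C(F)(F)F)cc2c(=O)cc(N3CCN(CC4CCC(O)CC4)CC3)sc12` gives 72.9%

Compound 3 stands highest of the three, beyond the scatter from both others. Compound 4 `O=c1cc(N2CCN(CC3CCC(O)CC3)CC2)sc2c([N+](=O)[O-])cc(C(F)(F)F)cc12` has nitro in place of amino on an aromatic carbon in the shared core. For the measured compounds named here, the one measured step, a number 55.4 percentage points lower from compound 1 to compound 2 (beyond the scatter), lies at a carbonyl carbon elsewhere, so it shows only how far this assay can move. Compound 1 and compound 2 carry nitro but also an ester, so neither isolates this exchange. A moderate step down is expected, with wide uncertainty. For compound 4 the estimated value is 60%, with an expected range of 35% to 82% as its limits. The expected step is a number 12.9 percentage points lower from compound 3 to compound 4 (beyond the scatter) on this estimate.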

Compound 4, percent of the compound remaining: 72.7%
Beside the measured number, compound 4's estimate is 12.7 percentage points below it, and the stated range covers the measured number.
By their numbers in this assay, from the lowest: compound 2; then compound 1; then compounds 4 and 3 (each within the scatter of the next).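

In this assay, nitro and amino on this aromatic carbon, meta to a trifluoromethyl group, cannot be told apart: the exchange gives a number 0.2 percentage points lower from compound 3 to compound 4 (within the scatter). With nitro held, hydrogen in place of (furan-2-yl)carbonyl on the oxygen gives a number 71.7 percentage points higher from compound 2 to compound 4 (beyond the scatter), and hydrogen in place of benzoyl gives a number 16.3 percentage points higher from compound 1 to compound 4 (beyond the scatter), so the size of the step depends on the acyl group replaced. Nothing available explains either result.

On these data alone, whether this position tolerates other groups, such as a nitrile or a methoxy group, stays open. So does whether the nitro and amino exchange stays within the scatter when the oxygen carries benzoyl or (furan-2-yl)carbonyl.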